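Swapping a Pyridinyloxy Arm for a Nitrile

The source may hold more compounds than are shown below. What is called first, only, known or untested is meant among the compounds shown, and "the series" means these compounds.

Two compounds have been measured in a functional assay for inhibition of sodium/hydrogen exchanger (Oryctolagus cuniculus); a higher number here means a weaker inhibitor, a lower number a stronger inhibitor:
Compound 1, `CCCc1cc(C)c(C(=O)N=C(N)N)cc1S(C)(=O)=O`: 5.7 nM
Compound 2, `Cc1c(C(=O)N=C(N)N)cc(S(C)(=O)=O)c(Oc2cccnc2)c1C`: 23 nM

Both share the same acylguanidine core carrying a methylsulfonyl group; they differ in what sits at the remaining positions on the aromatic ring. Of the two numbers, compound 2 gives the higher one, and its nearest neighbour, compound 1, gives a lower value in this assay; the gap between them is larger than the usual scatter of repeated measurements, so compound 1 is the stronger inhibitor of the pair.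

Compound 3, `Cc1c(C(=O)N=C(N)N)cc(S(C)(=O)=O)c(C#N)c1C`, has not yet been measured. It arises from compound 2 by one change: cyano in place of (pyridin-3-yl)oxy on an aromatic carbon. A large ring-bearing arm is thus traded for a small two-atom group at the same position. Among the compounds with values here, no measured pair shows exactly this exchange, so the direction is open. A modest change in either direction, or none beyond the scatter, is expected; the estimate for compound 3 in this assay is 15 nM, within 5 nM to 50 nM, corresponding to an expected step of a 1.5-fold lower number from compound 2 to compound 3 (0.19 log units; within the scatter).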

Compound 3, half-maximal inhibitory concentration: 370 nM
The estimate for compound 3 lay 25-fold (1.39 log units) below the measured number; the whole stated range lies below it.
By their numbers in this assay, from the lowest: compound 1; then compound 2; then compound 3.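

In this assay, placing cyano where (pyridin-3-yl)oxy stood gives a 16-fold higher number from compound 2 to compound 3 (1.21 log units; beyond the scatter), so this position, ortho to a methylsulfonyl group and to a methyl group, is far from indifferent to what it carries. Within the data shown here, this single pair ties the ring-bearing arm to the stronger inhibition and the small cyano to the weaker, which the earlier compounds could not show, as they differ from each other in more than one place. Nothing available here bears on why inhibition falls so steeply with this exchange.

The change removes the ring and its linking oxygen together while bringing in a triple bond, so the pair cannot tell whether the loss comes from losing the pyridine ring, losing the oxygen, or adding the cyano itself. A methoxy group would keep the oxygen without the ring, a phenoxy group would keep the arm without the ring nitrogen, and a plain hydrogen or an amine at this carbon would show how the position behaves without either group.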